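Swapping a thiophene for fluorophenyl on a triazole

This account rests on a few compounds, and the source may have more. Where it says the series, first, only, none or still open, it means among the compounds named here.

Three compounds share one core, a triazole joined through a short amide link to a thiazole, and differ only in the aromatic group attached to the triazole. Compound 1 `COc1ccc(-c2cn(CC(=O)Nc3nccs3)nn2)cc1` carries a 4-methoxyphenyl group; in a functional assay on BMDM cells (Mus musculus, strain C57BL/6) for inhibition, with a stated time of 2 days (a higher number here means a weaker inhibitor, a lower number a stronger inhibitor), compound 1 gives 510 nM. Compound 2 `O=C(Cn1cc(-c2cccs2)nn1)Nc1nccs1` carries a thiophen-2-yl group instead. In this assay compound 2 gives > 30000 nM, which is a limit of the assay rather than a measured number. Of the two values shown, compound 2 therefore stands at the weak end, at the limit described by the limit of > 30000 nM in this assay, at which 1 of the 2 values shown sits, while compound 1 sits well inside the measurable range.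

Compound 3 `O=C(Cn1cc(-c2ccc(F)cc2)nn1)Nc1nccs1` is the next step from compound 2. The change is 4-fluorophenyl in place of thiophen-2-yl on an aromatic carbon. A six-membered carbon ring returns to the position where compound 1 also bears a six-membered ring, so compound 3 is expected to move back toward the measurable range, with an estimated step of an at least 15-fold lower number from compound 2 to compound 3 (1.17 log units; beyond the scatter). Compound 3 is expected to reach about 2000 nM in this assay, within a range of 400 nM to 20000 nM.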

Compound 3, half-maximal inhibitory concentration: 190 nM
For compound 3 the middle estimate is 11-fold (1.02 log units) above the measured one; the whole stated range lies above it.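

The swap of thiophen-2-yl for 4-fluorophenyl on this aromatic carbon of the shared core gives an at least 150-fold lower number from compound 2 to compound 3 (2.19 log units; beyond the scatter) in this assay, so the group at this one place can decide whether inhibition is measurable at all in this series. That step is a minimum and not an exact size, because compound 2 stands at a limit of the assay and not at a measured number: the limit of > 30000 nM in this assay, at which 1 of the 3 values shown sits.

Among the two compounds with a six-membered ring at this place, fluoro in place of methoxy gives a 2.7-fold lower number from compound 1 to compound 3 (0.43 log units; beyond the scatter), a modest step but one beyond the scatter, so methoxy is not required for a measurable value and the group on that ring also shifts the number.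

On these data alone, what plain phenyl, or a phenyl bearing an amine or a carboxylic acid, would give at this place remains open, so the share of the ring and the share of its substituent cannot yet be separated. As far as these compounds go, with thiophen-2-yl as the only five-membered ring here, it is also open whether a furan would fall as far.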